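Alpha-methyl variation on the glycine benzyl ester amide

A few compounds are considered here, and "the series" means these few. Any claim that something is new, unique, unknown or untested is made for them only; others in the source may bear on it.

Measured so far in a functional assay on the whole organism (Tail, strain ICR) with Mus musculus as the target, in the tail flick test, with a stated time of 90 min, at a dose of 25 umol/kg by the oral route; a higher number here means a stronger effect of the compound at the dose given, a lower number a weaker effect:
compound 1 `O=C(CN(c1nc(Cl)nc2[nH]cnc12)C1CC1)N[C@@H](CC(=O)OCc1ccccc1)C(=O)OCc1ccccc1` gives 15.6%
compound 2 `C[C@H](NC(=O)CN(c1nc(Cl)nc2[nH]cnc12)C1CC1)C(=O)O` gives 43.5%
compound 3 `O=C(CN(c1nc(Cl)nc2[nH]cnc12)C1CC1)NCC(=O)OCc1ccccc1` gives 27.2%

Compound 3 stands second of the three numbers; compound 1 lies below it by a step beyond the scatter, and compound 2 lies above it by a step beyond the scatter.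

Compound 4 `C[C@H](NC(=O)CN(c1nc(Cl)nc2[nH]cnc12)C1CC1)C(=O)OCc1ccccc1` is the next compound, not yet measured. It differs from compound 3 in one place: methyl in place of hydrogen on a saturated chain carbon bound to an amide-type nitrogen and a carbonyl carbon

For the measured compounds named here, only one measured step concerns the same place on the chain, the saturated chain carbon bound to an amide-type nitrogen and a carbonyl carbon: a number 11.6 percentage points higher from compound 1 to compound 3 (beyond the scatter), where a hydrogen took the place of the larger (benzyloxycarbonyl)methyl. The step to compound 4 runs the other way in kind, a methyl entering where hydrogen stood, but the entering group is a single carbon rather than the longer chain that left between compound 1 and compound 3. Going by the values given here, compound 2 also carries the methyl and gives 43.5%, but it differs from compound 4 in the acid against the benzyl ester, so no direct step links them. Compound 4 is therefore expected to stay close to compound 3, with a number 1.8 percentage points higher from compound 3 to compound 4 (within the scatter) likely within the scatter, and the estimate for compound 4 is 29%, within 15% to 45%.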

Compound 4, a percentage reported as activity, at one dose (the size of the read-out at that dose, not a potency): 44.2%
Estimate against measurement, compound 4: 15.2 percentage points below; the measured number falls inside the stated range.
By their numbers in this assay, from the lowest: compound 1; then compound 3; then compounds 2 and 4 (each within the scatter of the next).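

In this assay, for the compounds shown here, a single methyl on the saturated chain carbon bound to an amide-type nitrogen and a carbonyl carbon carries more weight than the one earlier step at this place could show: a number 17 percentage points higher from compound 3 to compound 4 (beyond the scatter), and a number 28.6 percentage points higher from compound 1 to compound 4 (beyond the scatter). At this carbon, methyl therefore reads above both hydrogen and the (benzyloxycarbonyl)methyl of compound 1, so the series does not simply favour the smallest group here. With the methyl in place, the benzyl ester and the free acid cannot be told apart, a number 0.7 percentage points higher from compound 2 to compound 4 (within the scatter), and nothing available bears on the reason for any of these steps.

Open, on these data alone, is how far the gain extends along a series of groups at this carbon: an ethyl or a longer chain would show where the number turns down on the way to the (benzyloxycarbonyl)methyl of compound 1. Also open, as far as these compounds go, is whether the benzyl ester and the acid remain level without the methyl, which the glycine carboxylic acid, with hydrogen at this carbon, would settle.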